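The compounds below may be only part of what the source reports. "The series", "measured", "known", "first", "only" and "open" are said of these compounds alone.

Two measured compounds share one core, and a third is set beside them. Compound 1, `CCc1c(F)c(N)c2c(=O)cc(-c3ccc(N)c(F)c3)oc2c1F`, is the parent of the pair. Compound 2, `CCCOCc1c(F)c(N)c2c(=O)cc(-c3ccc(N)c(F)c3)oc2c1F`, carries a propoxy in place of methyl on a saturated chain carbon bound to an aromatic carbon. The read-out throughout is a functional assay on HeLa cells (Homo sapiens) for cytotoxicity, read by neutral red uptake, with a stated time of 3 days; on this read-out higher numbers stand for weaker inhibition and lower numbers for stronger inhibition. In this assay compound 1 gives > 100000 nM, which is a limit of the assay and not a number. In this assay, for the measured compounds named here, compound 2 gives 78000 nM, the only number among the two values shown. Going by the values given here, the one measured comparison is an at least 1.2-fold lower number from compound 1 to compound 2 (0.10 log units; that floor lies within the scatter), and it is bounded by the limit of > 100000 nM in this assay, at which 1 of the 2 values shown sits.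

Compound 3, `CCCCCCOCc1c(F)c(N)c2c(=O)cc(-c3ccc(N)c(F)c3)oc2c1F`, differs from compound 2 by propyl in place of hydrogen on a saturated chain carbon, three bonds along the chain from an oxygen on a saturated carbon, so that the chain runs from propyl to hexyl. Among the compounds with values here, the single measured step, also a lengthening of the chain at this place, stayed within the scatter, so no step beyond the scatter is expected here; the change from compound 2 to compound 3 is estimated as a 1.3-fold lower number from compound 2 to compound 3 (0.11 log units; within the scatter). Compound 3 is therefore expected to give 60000 nM in this assay, with a range from 20000 nM to 150000 nM.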

Compound 3, half-maximal inhibitory concentration: > 100000 nM
Compound 3 was reported as a limit; the forecaster's own chance of this, stated with the estimate: 30%; at least 1.6-fold (0.22 log units) between middle value and limit.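

In this assay compound 3, with its hexyl chain, gives > 100000 nM, which is a limit of the assay and not a number. Lengthening propyl to hexyl at this place gives an at least 1.2-fold higher number from compound 2 to compound 3 (0.10 log units; that floor lies within the scatter), so only a floor is known for this change; it shows no lowering of the number with the longer chain, and like the first step on this chain it cannot be told from the scatter. The step linking compound 1 with compound 3 cannot be read, and the series now sits mostly at one edge of what the assay reports: the limit of > 100000 nM in this assay, at which 2 of the 3 values shown sit.

The compounds shown leave open how large the true step to hexyl is, and what a butyl or pentyl chain on the same oxygen would give. They also leave open what an amine or a carboxylic acid in place of the hexyl chain would give in this assay, and whether any group at this place would bring the number clearly away from the limit.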